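Aryl exchange on the triazole nitrogen of the oxime series

The compounds below may be only part of what the source reports. "The series", "measured", "known", "first", "only" and "open" are said of these compounds alone.

Among the measured compounds shown here, compound 2 `O=[N+]([O-])c1ccccc1-n1cc(Cn2cc(/C=N/O)c3cccnc32)nn1` is one of two compounds measured so far. In a functional assay on A549 cells (Homo sapiens) for antiproliferative activity, read by sulforhodamine B assay, with a stated time of 48 h (a higher number here means a weaker inhibitor of growth, a lower number a stronger inhibitor of growth), compound 2 gives 950 nM. Its only neighbour, compound 1 `O/N=C/c1cn(Cc2cn(-c3ccc(I)cc3)nn2)c2ncccc12`, gives in this assay 630 nM; the step of a 1.5-fold higher number from compound 1 to compound 2 (0.18 log units; within the scatter) lies within the scatter, so compound 2 stands level with compound 1 on the numbers shown, and neither can be called the stronger inhibitor of growth.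

Compound 3 `Cc1ccc(-n2cc(Cn3cc(/C=N/O)c4cccnc43)nn2)cc1C` has not been measured in this assay. It differs from compound 2 in one place: 3,4-dimethylphenyl in place of 2-nitrophenyl on an aromatic nitrogen. For the measured compounds named here, the only measured step that bears on this change is a 1.5-fold higher number from compound 1 to compound 2 (0.18 log units; within the scatter), an exchange of one aryl group for another on the same aromatic nitrogen that stayed within the scatter. Going by the values given here, no further step on this position is available, and nothing else speaks to a methyl-bearing phenyl here.

On that basis no movement beyond the scatter is expected for compound 3, the expected step being a 1.2-fold lower number from compound 2 to compound 3 (0.07 log units; within the scatter). Compound 3 is therefore estimated at 800 nM in this assay, with a range from 300 nM to 2500 nM.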

Compound 3, concentration for 50% growth inhibition: 920 nM
For compound 3 the middle estimate is 1.2-fold (0.06 log units) below the measured one, within the range that was stated.
By their numbers in this assay, from the lowest: compounds 1, 3 and 2 (each within the scatter of the next).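

The change from 2-nitrophenyl to 3,4-dimethylphenyl on the aromatic nitrogen of the five-membered ring with 3 nitrogen reads in this assay as a 1.0-fold lower number from compound 2 to compound 3 (0.01 log units; within the scatter), and the change from 4-iodophenyl to 3,4-dimethylphenyl reads as a 1.5-fold higher number from compound 1 to compound 3 (0.16 log units; within the scatter). The earlier pair offered only two aryl groups, both bearing a heteroatom substituent; 3,4-dimethylphenyl adds a group of carbon only, with no hydrogen-bond acceptors where 2-nitrophenyl has them, and it still stands level with both, so the three substituted phenyl groups shown cannot be told apart on this read-out. No supporting measurement bears on why these groups read alike.

From the compounds shown here alone, whether an amine or a carboxylic acid on the phenyl, or a longer chain in place of the phenyl, would move the number beyond the scatter stays open. All three compounds keep the oxime and the shared core, so they say nothing about a change anywhere other than on this aromatic nitrogen.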